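This account rests on a few compounds, and the source may have more. Where it says the series, first, only, none or still open, it means among the compounds named here.

Among the compounds with values here, compound 2, `O=C(Nc1cc(-c2ccccc2)nn1-c1ccccc1)C1=CCCCC1`, is the only compound for which a definite number is known in an assay on HEK293 cells for displacement of a labelled ligand from metabotropic glutamate receptor 5 (Rattus norvegicus); a higher number here means a weaker inhibitor, a lower number a stronger inhibitor; in this assay compound 2 gives 4470 nM. Compound 1, `O=C(Nc1cc(-c2ccccc2)nn1-c1ccccc1)c1ccncc1`, reaches only a limit of the assay in this assay, where compound 1 gives > 10000 nM. Going from compound 1 to compound 2 means swapping pyridin-4-yl for cyclohex-1-en-1-yl on the carbonyl carbon, and the step is an at least 2.2-fold lower number from compound 1 to compound 2 (0.34 log units; beyond the scatter); this rests on (the limit of > 10000 nM in this assay, at which 1 of the 2 values shown sits).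

Compound 3, `O=C(Nc1cc(-c2ccccc2)nn1-c1ccccc1)C1CCCCC1`, differs from compound 2 in a single place: cyclohexyl in place of cyclohex-1-en-1-yl on a carbonyl carbon. Within the data shown here, the one measured step concerns a quite different exchange, an aromatic heterocycle against a non-aromatic carbocycle, and says nothing about removing the one double bond outside aromatic rings while the ring itself stays. With no direct guide, the change from compound 2 to compound 3 is expected to stay within the usual scatter of this assay, in either direction. For compound 3 the expected value in this assay is 5000 nM, with a range from 1500 nM to 15000 nM, which means an expected step of a 1.1-fold higher number from compound 2 to compound 3 (0.05 log units; within the scatter).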

Compound 3, inhibition constant: 10100 nM
Compound 3: the middle estimate sits 2.0-fold (0.31 log units) below what was measured, and the stated range covers the measured number.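

On the carbonyl carbon, a small edit to the ring is enough to register in this assay: cyclohexyl in place of cyclohex-1-en-1-yl gives a 2.3-fold higher number from compound 2 to compound 3 (0.35 log units; beyond the scatter). Both groups are six-membered carbon rings with the same count of heavy atoms, and the one double bond outside aromatic rings is what separates them, so this position responds to more than the choice between a pyridine-type ring and a carbon ring. From the compounds shown here alone, compound 1 gives > 10000 nM, which is a limit of the assay and not a number, so the step from it to compound 3 cannot be read and the order of these two stays unknown: the limit of > 10000 nM in this assay, at which 1 of the 3 values shown sits.

This single pair cannot show whether the double bond is a general advantage at this position, since the modest step rests on one exchange in one assay. Also open, going by these compounds, is how other groups on the carbonyl carbon would compare with compound 2, such as a phenyl ring, a smaller cyclopentyl ring, an open hexyl chain, or a piperidine ring carrying an amine.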